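Trifluoromethyl in place of fluoro: working notes

The compounds below may be only part of what the source reports. "The series", "measured", "known", "first", "only" and "open" are said of these compounds alone.

Measured so far in an assay on mitochondria from L6 cells (Rattus norvegicus) for activation, with a stated time of 90 min; a lower number here means that less compound is needed, a higher number that more compound is needed for the effect:
compound 1 `Oc1nc2nonc2nc1Nc1ccc(OCC(F)(F)F)c(F)c1` gives 10400 nM
compound 2 `Oc1nc2nonc2nc1Nc1ccc(OCC(F)(F)F)c(C(F)(F)F)c1` gives 4000 nM
compound 3 `Oc1nc2nonc2nc1Nc1ccc(F)cc1` gives 38600 nM

Compound 4 `Oc1nc2nonc2nc1Nc1ccc(C(F)(F)F)cc1` is not yet measured in this assay.

Compound 3 has the highest number of the three; it stands nearest to compound 1 and furthest from compound 2, both gaps beyond the scatter. The difference between the core of compound 1 and the core of compound 3 is not broken down here.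

One step is measured directly: a 2.6-fold lower number from compound 1 to compound 2 (0.41 log units; beyond the scatter), the change being (trifluoromethyl in place of fluoro on an aromatic carbon). Compound 4 carries the same kind of change relative to compound 3, namely (trifluoromethyl in place of fluoro on an aromatic carbon). The surroundings are not the same: in compound 2 the entering group sits ortho to a 2,2,2-trifluoroethoxy group and meta to a large group, whereas in compound 4 it sits para to a large group, so the precedent is a single one with different surroundings.

For compound 4 a step of a 2.6-fold lower number from compound 3 to compound 4 (0.41 log units; beyond the scatter) is expected, resting on a 2.6-fold lower number from compound 1 to compound 2 (0.41 log units; beyond the scatter). Compound 4 is therefore estimated at 15000 nM, with a range from 6000 nM to 38000 nM.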

Compound 4, half-maximal effective concentration: 10400 nM
Estimate against measurement, compound 4: 1.4-fold (0.16 log units) above, and the stated range covers the measured number.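

In this assay, trifluoromethyl in place of fluoro on an aromatic carbon brings a 3.7-fold lower number from compound 3 to compound 4 (0.57 log units; beyond the scatter), in the same direction as the step already seen on the other core. Set side by side, the two steps do not differ, so within this small set the change carries from one core to the other with much the same size: the same change on two cores in this assay, a 2.6-fold lower number (0.41 log units; beyond the scatter) from compound 1 to compound 2 and a 3.7-fold lower number (0.57 log units; beyond the scatter) from compound 3 to compound 4, 1.4-fold (0.15 log units) apart, within the scatter of two such steps

Among the compounds shown here, this agreement rests on only two pairs in a single assay, with the entering group in different surroundings in each, so it supports no general rule for the series and gives no explanation for the step.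

The compounds shown leave open how a nitrile, a carboxylic acid or an amine in the same place would compare with fluoro and trifluoromethyl, and whether a longer chain such as pentafluoroethyl would extend the step. They also leave open whether the step would hold on a core with a substituent other than the 2,2,2-trifluoroethoxy group, such as a methoxy group.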